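This account rests on a few compounds, and the source may have more. Where it says the series, first, only, none or still open, it means among the compounds named here.

Measured compounds:
Compound 1 `N#Cc1cccnc1N1CCN([C@@H]2CN[C@H](C(=O)N3CCSC3)C2)CC1` gives 1.2 nM in an assay on a cell-free system (plasma) for inhibition of Dipeptidyl peptidase 4 (Rattus norvegicus), read by fluorescence; a higher number here means a weaker inhibitor, a lower number a stronger inhibitor.
Compound 2 `O=C([C@@H]1C[C@H](N2CCN(c3ccc(Br)cc3)CC2)CN1)N1CCSC1` gives 9 nM in this assay.
Compound 3 `O=C([C@@H]1C[C@H](N2CCN(c3ccccc3Cl)CC2)CN1)N1CCSC1` gives 10.9 nM in this assay.

Compound 3 and compound 2 lie within the scatter of each other, as a 1.2-fold higher number from compound 2 to compound 3 (0.08 log units; within the scatter) shows; compound 1 stands well below both, as a 9.1-fold higher number from compound 1 to compound 3 (0.96 log units; beyond the scatter) shows. Compound 4 `N#Cc1ccc(N2CCN([C@@H]3CN[C@H](C(=O)N4CCSC4)C3)CC2)cc1` carries the change (4-cyanophenyl in place of 2-chlorophenyl on an amine nitrogen in a ring). Going by the values given here, two steps bear on it: the step from the nitrile-bearing aromatic group of compound 1 to the chlorophenyl was large, while the exchange of two halophenyl groups was flat. Compound 4 keeps a phenyl ring but brings in a nitrile, so the expected step of a 1.8-fold lower number from compound 3 to compound 4 (0.26 log units; within the scatter) is a modest fall in number, short of compound 1. Compound 4 is expected at 6 nM, range 2 nM to 18 nM.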

Compound 4, half-maximal inhibitory concentration: 4.7 nM
The estimate for compound 4 lay 1.3-fold (0.11 log units) above the measured number; measured number inside the range.
By their numbers in this assay, from the lowest: compound 1; then compounds 4, 2 and 3 (each within the scatter of the next, the first and the last beyond it).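

In this assay, the change from 2-chlorophenyl to 4-cyanophenyl on this amine nitrogen is a step beyond the scatter, a 2.3-fold lower number from compound 3 to compound 4 (0.37 log units; beyond the scatter), yet cyano in place of bromo at the same aryl group stays within it, a 1.9-fold lower number from compound 2 to compound 4 (0.28 log units; within the scatter). A nitrile on a phenyl ring does not reach the level of the 3-cyanopyridin-2-yl group, a 3.9-fold higher number from compound 1 to compound 4 (0.59 log units; beyond the scatter), so the presence of a nitrile alone does not account for compound 1. No evidence on the cause of these steps is at hand.

Going by these compounds, whether the remaining gap to compound 1 follows the ring nitrogen of the 3-cyanopyridin-2-yl group or the place of its nitrile stays open. On these data alone, how a carboxylic acid or an amine in place of the nitrile would read is also open.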